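Dimethylamino to Azetidin-1-yl: Expecting Compound 4

The source may report more compounds than this note shows. Statements on the series, on what has been measured and on what is new or still open speak of the compounds shown alone.

The compounds here share one core, carrying a nitrile on a pyrrolidine amide, and differ in one substituent on a saturated ring carbon. They were tested in an assay on the whole organism (plasma, strain Sprague-Dawley) for inhibition of Dipeptidyl peptidase 4 (Rattus norvegicus), with a stated time of 6 h, at a dose of 1 mg/kg by the oral route; a higher number here means more inhibition at the dose given (going by the name of the read-out), a lower number less inhibition. Compound 1 `CCC[C@@H]1CN[C@H](C(=O)N2CCC[C@H]2C#N)C1` gives 50%. Compound 2 `N#C[C@@H]1CCCN1C(=O)[C@@H]1C[C@H](C(=O)N2CCCCCCC2)CN1` gives 63%. Compound 3 `CN(C)C(=O)[C@@H]1CN[C@H](C(=O)N2CCC[C@H]2C#N)C1` gives 76%, the highest of the three, with both neighbours beyond the scatter: the step of a number 26 percentage points higher from compound 1 to compound 3 (beyond the scatter) and the step of a number 13 percentage points higher from compound 2 to compound 3 (beyond the scatter) both rise toward compound 3.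

Compound 4 `N#C[C@@H]1CCCN1C(=O)[C@@H]1C[C@H](C(=O)N2CCC2)CN1` has not yet been measured. It differs from compound 3 by azetidin-1-yl in place of dimethylamino on a carbonyl carbon. Among the measured compounds shown here, the step that bears on this is the one from compound 2 to compound 3, where a large eight-membered ring on the carbonyl carbon gave way to the small dimethylamino group and the inhibition rose. Azetidin-1-yl is only one heavy atom larger than dimethylamino and far smaller than the eight-membered ring, so the expected change is small: the estimated step of a number 6 percentage points lower from compound 3 to compound 4 (within the scatter) is expected to lie within the scatter, if anything slightly downward. Compound 4 is therefore expected to give about 70%, estimated between 55% and 85%.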

Compound 4, a percentage reported as inhibition, in the whole organism at one dose (the size of the read-out at that dose, not a potency): 77%
The estimate for compound 4 lay 7 percentage points below the measured number, within the range that was stated.
By their numbers in this assay, from the lowest: compound 1; then compound 2; then compounds 3 and 4 (each within the scatter of the next).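

Azetidin-1-yl in place of dimethylamino on a carbonyl carbon gives a number 1 percentage points higher from compound 3 to compound 4 (within the scatter) in this assay, so closing this small group into a four-membered ring makes no difference that this read-out can resolve. The same shared core also gives a number 14 percentage points higher from compound 2 to compound 4 (beyond the scatter) when the eight-membered ring is replaced by azetidin-1-yl, and this places compound 2 beyond the scatter of both small-group amides; having a ring at this position therefore does not by itself set compound 2 apart, while the eight-membered ring and the four-membered ring do differ here. The rise over the propyl compound also holds for the new amide, with a number 27 percentage points higher from compound 1 to compound 4 (beyond the scatter) and so a second (azetidin-1-yl)carbonyl example alongside the dimethylcarbamoyl of compound 3.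

Nothing available here explains why these numbers fall as they do. Rings of intermediate size on the carbonyl carbon, such as pyrrolidin-1-yl or piperidin-1-yl, remain open, so the ring size at which the read-out starts to drop from the level of compound 4 is still unknown.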